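Notes on the benzylic aryl variation, cytotoxicity

The source may report more compounds than this note shows. Statements on the series, on what has been measured and on what is new or still open speak of the compounds shown alone.

The series shares one core; compound 1 `CC1(Cc2ccc(/C(N)=N/O)cc2)CC(S(=O)(=O)c2ccc(F)cc2)=C(c2ccc(/C(N)=N/O)cc2)O1`, compound 2 `CC1(Cc2ccccc2C(F)(F)F)CC(S(=O)(=O)c2ccc(F)cc2)=C(c2ccc(/C(N)=N/O)cc2)O1` and compound 3 `COc1cc(CC2(C)CC(S(=O)(=O)c3ccc(F)cc3)=C(c3ccc(/C(N)=N/O)cc3)O2)cc(OC)c1OC` differ only in the aryl group on a saturated chain carbon bound to a saturated ring carbon. In an ADME assay on cells (Peritoneal macrophage, Mus musculus, strain Balb/c) for cytotoxicity, read by resazurin assay, with a stated time of 72 h (on this read-out higher numbers stand for lower toxicity in this test and lower numbers for higher toxicity in this test), compound 1 gives 42200 nM, compound 2 gives 105000 nM and compound 3 gives 92300 nM, the second highest of the three. The steps were a 2.5-fold higher number from compound 1 to compound 2 (0.40 log units; beyond the scatter), a 2.2-fold higher number from compound 1 to compound 3 (0.34 log units; beyond the scatter) and a 1.1-fold lower number from compound 2 to compound 3 (0.06 log units; within the scatter). Compound 4 `CC1(Cc2ccc(-c3ccccc3)cc2)CC(S(=O)(=O)c2ccc(F)cc2)=C(c2ccc(/C(N)=N/O)cc2)O1` carries 4-phenylphenyl in place of 3,4,5-trimethoxyphenyl on a saturated chain carbon bound to a saturated ring carbon. The two exchanges of the aryl group at this place away from compound 1 were modest and alike, and the exchange between compound 2 and compound 3 stayed within the scatter, so no change beyond the scatter is expected here. The expected step is a 1.0-fold lower number from compound 3 to compound 4 (0.01 log units; within the scatter). Compound 4 is estimated at 90000 nM, between 45000 nM and 180000 nM.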

Compound 4, half-maximal cytotoxic concentration: 33900 nM
Compound 4: the middle estimate sits 2.7-fold (0.42 log units) above what was measured; measured number below the stated range.
By their numbers in this assay, from the lowest: compounds 4 and 1 (each within the scatter of the next); then compounds 3 and 2 (each within the scatter of the next).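

Exchanging aryl groups at this place can move the number in this assay: 4-phenylphenyl in place of 3,4,5-trimethoxyphenyl gives a 2.7-fold lower number from compound 3 to compound 4 (0.44 log units; beyond the scatter), and in place of 2-(trifluoromethyl)phenyl it gives a 3.1-fold lower number from compound 2 to compound 4 (0.49 log units; beyond the scatter). With a 1.2-fold lower number from compound 1 to compound 4 (0.10 log units; within the scatter), compound 4 stays within the scatter of compound 1, so the four compounds fall into two pairs, compounds 1 and 4 and compounds 2 and 3. No measurement at hand accounts for this split. Going by these compounds, whether an unsubstituted phenyl or an aryl group bearing a carboxylic acid at this place would join either pair remains open.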